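This account rests on a few compounds, and the source may have more. Where it says the series, first, only, none or still open, it means among the compounds named here.

In a functional assay on KB cells (Homo sapiens) for antiproliferative activity, read by sulforhodamine B assay, with a stated time of 3 days (a lower number here means that less compound is needed, a higher number that more compound is needed for the effect), three compounds sharing one core differ only in an aryl group. Compound 1 `CCC1=C(O)c2c(oc(-c3ccc(COC)cc3)cc2=O)C(CC)(CC)C1=O` gives > 52.4 uM, which is a limit and not a number. Compound 2 `CCC1=C(O)c2c(oc(-c3cccc(C)c3)cc2=O)C(CC)(CC)C1=O` gives 49.7 uM. Compound 3 `CCC1=C(O)c2c(oc(-c3cc(C)c(C)cc3C)cc2=O)C(CC)(CC)C1=O` gives 8.2 uM, the lowest value among the three.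

Compound 4 `CCC1=C(O)c2c(oc(-c3ccc(OC)c(F)c3)cc2=O)C(CC)(CC)C1=O` has 3-fluoro-4-methoxyphenyl in place of 2,4,5-trimethylphenyl, on an aromatic carbon next to the ring oxygen: 3-fluoro-4-methoxyphenyl in place of 2,4,5-trimethylphenyl on an aromatic carbon.

For the measured compounds named here, two measured steps bear on this swap, as both change the group at this same place and end on the 2,4,5-trimethylphenyl group: a 6.1-fold lower number from compound 2 to compound 3 (0.78 log units; beyond the scatter), and an at least 6.3-fold lower number from compound 1 to compound 3 (0.80 log units; beyond the scatter). The remaining step, which involves neither that group nor the incoming one, is an at least 1.0-fold lower number from compound 1 to compound 2 (0.02 log units; that floor lies within the scatter). Going by the values given here, no tested compound carries the 3-fluoro-4-methoxyphenyl group, so the expectation is loose. Losing the 2,4,5-trimethylphenyl group should give back a modest step towards a higher number. The expected step is a 3.4-fold higher number from compound 3 to compound 4 (0.53 log units; beyond the scatter). For compound 4 the estimated value is 28 uM, with an expected range of 10 uM to 60 uM.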

Compound 4, concentration for half-maximal effect: 26.7 uM
Compound 4: the middle estimate sits 1.0-fold (0.02 log units) above what was measured, and the stated range covers the measured number.
By their numbers in this assay, from the lowest: compound 3; then compounds 4 and 2 (each within the scatter of the next). At a limit, above all of these: compound 1.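

In this assay, for the compounds shown here, compound 4 brings the first aryl group with a fluorine and an oxygen to the position next to the ring oxygen, and a 3.3-fold higher number from compound 3 to compound 4 (0.51 log units; beyond the scatter) shows that it does not keep the low number of compound 3. Against the 3-methylphenyl group, the result is a 1.9-fold lower number from compound 2 to compound 4 (0.27 log units; within the scatter), so these two aryl groups cannot be told apart here, and the 2,4,5-trimethylphenyl group remains the only one that stands apart from the others with a measured number. The step of an at least 1.9-fold lower number from compound 1 to compound 4 (0.29 log units; that floor lies within the scatter) starts from a limit and not a number, so it is only a floor: the limit of > 52.4 uM in this assay, at which 1 of the 4 values shown sits.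

The compounds shown leave open whether the fluorine or the methoxy group of compound 4 matters more, and which of the three methyl groups of compound 3 go with its lower number. Going by these compounds, it also remains open how this position would respond to an aryl group carrying an amine or a carboxylic acid.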